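The compounds below may be only part of what the source reports. "The series", "measured", "known", "first", "only" and "open" are said of these compounds alone.

Three measured compounds share one core and differ only in the group carried on an amide-type nitrogen. Compound 1 `Cc1cccc(NC(=O)COc2ccc(/C=C3\SC(=O)NC3=O)cc2)n1` bears a 6-methylpyridin-2-yl group there, and in a functional assay on MCF7 cells (Homo sapiens) for inhibition (a lower number here means a stronger inhibitor of growth, a higher number a weaker inhibitor of growth), compound 1 gives 28300 nM. Compound 2 `O=C(COc1ccc(/C=C2\SC(=O)NC2=O)cc1)Nc1ccccc1` carries a phenyl group and gives 74500 nM, while compound 3 `O=C(COc1ccc(/C=C2\SC(=O)NC2=O)cc1)Nc1ccc(Cl)cc1` carries a 4-chlorophenyl group and gives 51100 nM. For the measured compounds named here, compound 1 thus has the lowest number of the three, although its gap to compound 3 stays within the scatter; only the step of a 2.6-fold higher number from compound 1 to compound 2 (0.42 log units; beyond the scatter) lies beyond it.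

Compound 4 `O=C(COc1ccc(/C=C2\SC(=O)NC2=O)cc1)Nc1ccc(Br)cc1` differs from compound 1 in one place: 4-bromophenyl in place of 6-methylpyridin-2-yl on an amide-type nitrogen. Going by the values given here, two measured steps bear on this. The step of a 2.6-fold higher number from compound 1 to compound 2 (0.42 log units; beyond the scatter) shows that replacing the 6-methylpyridin-2-yl group with a phenyl group gives a modestly weaker inhibitor, and the step of a 1.8-fold higher number from compound 1 to compound 3 (0.26 log units; within the scatter) shows that a 4-chlorophenyl group gives no difference beyond the scatter. The step of a 1.5-fold lower number from compound 2 to compound 3 (0.16 log units; within the scatter) likewise stays within the scatter. Since a 4-bromophenyl group most resembles the 4-chlorophenyl group of compound 3, the step expected from compound 1 to compound 4 is a 1.7-fold higher number from compound 1 to compound 4 (0.23 log units; within the scatter), a slight rise in the number at the edge of the scatter. Compound 4 is therefore estimated at 48000 nM, within a range from 24000 nM to 96000 nM.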

Compound 4, concentration for 50% growth inhibition: 55100 nM
The estimate for compound 4 lay 1.1-fold (0.06 log units) below the measured number; the range from low to high includes it.
By their numbers in this assay, from the lowest: compounds 1, 3, 4 and 2 (each within the scatter of the next, the first and the last beyond it).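

In this assay the change to 4-bromophenyl, which removes the one hydrogen-bond acceptor of the leaving group, gives a 1.9-fold higher number from compound 1 to compound 4 (0.29 log units; within the scatter) and so, like the 4-chlorophenyl group of compound 3, does not separate from the 6-methylpyridin-2-yl group of compound 1. Among the rings of carbon only, bromo in place of chloro gives a 1.1-fold higher number from compound 3 to compound 4 (0.03 log units; within the scatter) and bromo in place of hydrogen gives a 1.4-fold lower number from compound 2 to compound 4 (0.13 log units; within the scatter), so the bromo group adds a second halogen example that cannot be told apart from either the chloro compound or the unsubstituted phenyl compound. For the compounds shown here, only the pair of compound 1 and compound 2 remains apart beyond the scatter, and nothing measured here gives a reason for any of these steps.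

All the groups shown on the amide-type nitrogen are six-membered aromatic rings, so it remains open how a cyclohexyl group, or a phenyl ring carrying a carboxylic acid or an amine, would compare. From the compounds shown here alone, it also remains open whether the methyl group or the ring nitrogen matters more in 6-methylpyridin-2-yl, which a plain pyridin-2-yl group or a 3-methylphenyl group could help to separate.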